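Cyclopentyl in place of 3-fluorophenyl: compound 3 to compound 4

The source may hold more compounds than are shown below. What is called first, only, known or untested is meant among the compounds shown, and "the series" means these compounds.

Measured in a functional assay on BaF3 cells (Mus musculus) for antiproliferative activity, read by CCK-8 assay and cell counting, with a stated time of 76 h; a lower number here means a stronger inhibitor, a higher number a weaker inhibitor:
- compound 1 `COc1cc2nccc(Oc3ccc(Nc4nn(C)cc4C(=O)NC45CCC(CC4)CC5)cc3)c2cc1C(N)=O`: > 10000 nM (a limit)
- compound 2 `COc1cc2nccc(Oc3ccc(Nc4nn(C)cc4C(=O)Nc4ccc(F)cc4)cc3)c2cc1C(N)=O`: 3060 nM
- compound 3 `COc1cc2nccc(Oc3ccc(Nc4nn(C)cc4C(=O)Nc4cccc(F)c4)cc3)c2cc1C(N)=O`: 4480 nM

Compound 3 stands level with compound 2 within the scatter, with a 1.5-fold higher number from compound 2 to compound 3 (0.17 log units; within the scatter). Within the data shown here, for compound 1 the only reading is the limit of > 10000 nM in this assay, at which 1 of the 3 values shown sits.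

The next compound is compound 4 `COc1cc2nccc(Oc3ccc(Nc4nn(C)cc4C(=O)NC4CCCC4)cc3)c2cc1C(N)=O`, with cyclopentyl in place of 3-fluorophenyl on an amide-type nitrogen.

The closest precedents are the two steps that replace the non-aromatic group of compound 1 with a fluorophenyl ring: an at least 3.2-fold lower number from compound 1 to compound 2 (0.51 log units; beyond the scatter) and an at least 2.2-fold lower number from compound 1 to compound 3 (0.34 log units; beyond the scatter). As far as these compounds go, both are bounded by a limit, so their true sizes remain open. The change planned here runs the opposite way, from aromatic to non-aromatic, although cyclopentyl is not the group carried by compound 1. The step of a 1.5-fold higher number from compound 2 to compound 3 (0.17 log units; within the scatter) offers no guide, as it only moves the fluorine.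

A modest rise to a higher number is therefore expected in this assay, comparable to those two steps in size. The expected change is a 2.2-fold higher number from compound 3 to compound 4 (0.35 log units; beyond the scatter). A reading at the limit of the assay is a real possibility. For compound 4 the estimate is 10000 nM, with an expected range of 4000 nM to 25000 nM.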

Compound 4, half-maximal inhibitory concentration: > 10000 nM
Compound 4 was reported as a limit; the forecaster's own chance of this, stated with the estimate: 45%; the middle value sits exactly at the limit.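

In this assay, an at least 2.2-fold higher number from compound 3 to compound 4 (0.34 log units; beyond the scatter) and an at least 3.2-fold higher number from compound 2 to compound 4 (0.51 log units; beyond the scatter), so both fluorophenyl compounds hold a lower number than the cyclopentyl amide, each by a step beyond the scatter. Until now, the aromatic ring on the amide-type nitrogen had been compared only with the group of compound 1; with compound 4 the same direction appears with a second, smaller non-aromatic ring, so the pattern no longer rests on one group and no compound shown goes against it. The values of compound 1 and compound 4 are both limits, so the step between them cannot be read and these two non-aromatic groups cannot be ranked: the limit of > 10000 nM in this assay, at which 2 of the 4 values shown sit.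

Still open, as far as these compounds go, is whether a plain phenyl ring on this nitrogen would read like the two fluorophenyl compounds, which would show whether the fluorine matters at all. Also open, from the compounds shown here alone, is how a benzyl group, a pyridyl ring or a fluorophenyl ring carrying an amine would read, and whether any of them would move the number clearly below those of compound 2 and compound 3.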